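Cytotoxicity notes on bridged diaryl amino ketones and oxime

The compounds below may be only part of what the source reports. "The series", "measured", "known", "first", "only" and "open" are said of these compounds alone.

Measured compounds:
Compound 1, `COc1ccc(C2CC3(N(C)C)CC(=O)C2C(c2ccc(OC)cc2)C3)cc1`: 52400 nM
Compound 2, `COc1ccc(C2CC3(N4CCCC4)CC(=O)C2C(c2ccc(OC)cc2)C3)cc1`: 41900 nM
Compound 3, `CN(C)C12C/C(=N\O)C(C(c3ccc(Cl)cc3)C1)C(c1ccc(Cl)cc1)C2`: 7820 nM

The read-out throughout is an ADME assay on L6 cells (Rattus norvegicus) for cytotoxicity; on this read-out lower numbers stand for stronger inhibition and higher numbers for weaker inhibition. Compound 1 and compound 2 share a core and differ only by pyrrolidin-1-yl in place of dimethylamino on a saturated ring carbon. That step, a 1.3-fold lower number from compound 1 to compound 2 (0.10 log units; within the scatter), is a small one. Compound 3 carries a different core; the difference between the core of compound 3 and the core of compound 1 is not broken down here. Compound 3 gives the lowest number of the three measured compounds, and its distance to compound 2 and to compound 1 lies beyond the scatter in each case.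

Compound 4, `O/N=C1\CC2(N3CCCC3)CC(c3ccc(Cl)cc3)C1C(c1ccc(Cl)cc1)C2`, has not yet been measured. It differs from compound 3 by pyrrolidin-1-yl in place of dimethylamino on a saturated ring carbon. Within the data shown here, this is the same kind of change as the one from compound 1 to compound 2, but the surroundings are not the same word for word: in the pair compound 1 and compound 2 the ring atom two ring bonds away bears a 4-methoxyphenyl group, whereas in the pair compound 3 and compound 4 it bears a 4-chlorophenyl group.

Among the measured compounds shown here, the only measured instance of this change is the step from compound 1 to compound 2, which is within the scatter. On that basis the step from compound 3 to compound 4 is expected to be small as well, a 1.2-fold lower number from compound 3 to compound 4 (0.08 log units; within the scatter), resting on a 1.3-fold lower number from compound 1 to compound 2 (0.10 log units; within the scatter) and on the value of compound 3, 7820 nM. Compound 4 is therefore estimated at 6500 nM in this assay, with an expected range from 3000 nM to 14000 nM.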

Compound 4, half-maximal inhibitory concentration: 12700 nM
Beside the measured number, compound 4's estimate is 2.0-fold (0.29 log units) below it, within the range that was stated.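

On the second core, pyrrolidin-1-yl in place of dimethylamino gives a 1.6-fold higher number from compound 3 to compound 4 (0.21 log units; within the scatter) in this assay and the two measured instances of the change do not differ beyond what repeated measurements allow: the same change on two cores in this assay, a 1.3-fold lower number (0.10 log units; within the scatter) from compound 1 to compound 2 and a 1.6-fold higher number (0.21 log units; within the scatter) from compound 3 to compound 4, 2.0-fold (0.31 log units) apart, within the scatter of two such steps

In this assay, the change therefore carries from the core of compound 1 to the core of compound 3 without a step beyond the scatter, and the opposite directions of the two steps carry no weight. Among these compounds, this does not show that the two cores respond identically or that the change would stay small on any further core, as only two pairs stand behind it, one with 4-methoxyphenyl groups and a ketone, the other with 4-chlorophenyl groups and an oxime.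

The compounds shown leave open whether another amine, such as piperidin-1-yl, morpholin-4-yl or a primary amine, would stay as close to dimethylamino on either core. They also leave open where a ketone with 4-chlorophenyl groups or an oxime with 4-methoxyphenyl groups would stand, so the distance of compound 3 from compound 1 cannot be divided between the aryl substituent and the oxime.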